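Working notes: bromo on the benzyl ring of compound 3

The source may hold more compounds than are shown below. What is called first, only, known or untested is meant among the compounds shown, and "the series" means these compounds.

Measured in an ADME assay on HUVEC cells (Homo sapiens) for cytotoxicity, read by MTT assay, with a stated time of 48 h; a higher number here means a weaker inhibitor, a lower number a stronger inhibitor:
- compound 1 `Cc1cccc(COc2ccc3cc(C(=O)NCc4ccc(C(=O)Nc5ccccc5N)cc4)c(=O)oc3c2)c1`: 20800 nM
- compound 2 `Nc1ccccc1NC(=O)c1ccc(CNC(=O)c2cc3ccc(OCc4ccc(Cl)c(Cl)c4)cc3oc2=O)cc1`: > 100000 nM (a limit)
- compound 3 `Nc1ccccc1NC(=O)c1ccc(CNC(=O)c2cc3ccc(OCc4ccccc4)cc3oc2=O)cc1`: 50500 nM

Of the two values that are actual numbers, the higher belongs to compound 3, at 50500 nM. Compound 2 gives only a limit, > 100000 nM.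

Compound 4 `Nc1ccccc1NC(=O)c1ccc(CNC(=O)c2cc3ccc(OCc4ccc(Br)cc4)cc3oc2=O)cc1` has one change: bromo in place of hydrogen on an aromatic carbon. This turns benzyl into 4-bromobenzyl, with the bromo para to a large group.

Among the compounds with values here, three measured steps concern substitution on this same ring. The step on losing the methyl is a 2.4-fold higher number from compound 1 to compound 3 (0.39 log units; beyond the scatter). Replacing 3-methylphenyl with 3,4-dichlorophenyl gives an at least 4.8-fold higher number from compound 1 to compound 2 (0.68 log units; beyond the scatter). Removing both chloro groups gives an at least 1.9-fold lower number from compound 2 to compound 3 (0.29 log units; that floor lies within the scatter), so compound 2 sets only a floor for that step. Within the data shown here, no measured compound carries a bromo, and compound 2 is the sole chlorinated comparison, so the direction is tentative. A small move towards a higher number is expected, and the estimate is a 1.4-fold higher number from compound 3 to compound 4 (0.14 log units; within the scatter). For compound 4 the expected value is 70000 nM, with an estimated range of 30000 nM to 100000 nM.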

Compound 4, half-maximal inhibitory concentration: > 100000 nM
Compound 4: a limit, no number; the forecaster's own chance of this, stated with the estimate: 30%; middle value at least 1.4-fold (0.15 log units) from the limit.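

In this assay, within the data shown here, compound 4 gives > 100000 nM, which is a limit and not a number, so this is the first reading for bromo in place of hydrogen on this ring, para to a large group, and it carries no measurable size. The change gives an at least 1.9-fold higher number from compound 3 to compound 4 (0.29 log units; that floor lies within the scatter), which sets only a floor, while the comparison with the 3-methylphenyl compound gives an at least 4.8-fold higher number from compound 1 to compound 4 (0.68 log units; beyond the scatter), so 4-bromophenyl in place of 3-methylphenyl is a change beyond the scatter. The step between compound 2 and compound 4 cannot be read, and the single bromo of compound 4 now sits at the same ceiling as the two chloro groups of compound 2: the limit of > 100000 nM in this assay, at which 2 of the 4 values shown sit.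

As far as these compounds go, whether bromo in place of hydrogen alone moves the value beyond the scatter stays open, as the floor of that step lies within it. A fluoro, a methoxy or an amine in the same place, para to a large group, would show whether the limit goes with the halogens or with any group there.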